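Para-Substituted Benzamides on a Quinoline Core: Predicting Methoxy

The source may hold more compounds than are shown below. What is called first, only, known or untested is meant among the compounds shown, and "the series" means these compounds.

Measured compounds:
Compound 1, `CCN1CCN(c2cc(C)c3cc(NC(=O)c4ccccc4F)ccc3n2)CC1`: 32600 nM
Compound 2, `CCc1ccc(C(=O)Nc2ccc3nc(N4CCN(CC)CC4)cc(C)c3c2)cc1`: 3060 nM
Compound 3, `CCN1CCN(c2cc(C)c3cc(NC(=O)c4ccc(Cl)cc4)ccc3n2)CC1`: 1530 nM

These three compounds were tested in a functional assay on MCF7 cells (Homo sapiens) for antiproliferative activity, read by MTT assay, with a stated time of 72 h; a lower number here means a stronger inhibitor, a higher number a weaker inhibitor. Compound 3 has the lowest number of the three: against compound 1 the gap is a 21-fold lower number from compound 1 to compound 3 (1.33 log units; beyond the scatter), while against compound 2 the step of a 2.0-fold lower number from compound 2 to compound 3 (0.30 log units; within the scatter) stays within the scatter, so compound 2 and compound 3 cannot be separated.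

Compound 4, `CCN1CCN(c2cc(C)c3cc(NC(=O)c4ccc(OC)cc4)ccc3n2)CC1`, has not yet been measured. It differs from compound 3 in one place: methoxy in place of chloro on an aromatic carbon. Going by the values given here, no measured step involves methoxy. The relevant comparisons are a 21-fold lower number from compound 1 to compound 3 (1.33 log units; beyond the scatter), where the change moved from 2-fluorophenyl to 4-chlorophenyl, and a 2.0-fold lower number from compound 2 to compound 3 (0.30 log units; within the scatter), where chloro replaced ethyl para to the carbonyl. Two different groups in this para position gave numbers within the scatter of each other, so a third group there is expected to land near them as well, with no step beyond the scatter. The step expected in this assay is a 1.6-fold higher number from compound 3 to compound 4 (0.21 log units; within the scatter). Compound 4 is estimated at 2500 nM, with a range from 800 nM to 8000 nM.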

Compound 4, half-maximal inhibitory concentration: 7690 nM
Estimate against measurement, compound 4: 3.1-fold (0.49 log units) below; low and high end bracket the measured number.
By their numbers in this assay, from the lowest: compounds 3 and 2 (each within the scatter of the next); then compound 4; then compound 1.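

In this assay, swapping in methoxy gives a 5.0-fold higher number from compound 3 to compound 4 (0.70 log units; beyond the scatter) and a 2.5-fold higher number from compound 2 to compound 4 (0.40 log units; beyond the scatter) so the group on this aromatic carbon does matter, even though chloro and ethyl could not be told apart there. The methoxy compound still compares well with the 2-fluorophenyl amide, with a 4.2-fold lower number from compound 1 to compound 4 (0.63 log units; beyond the scatter) so all three groups para to a large group give lower numbers than compound 1, though not by equal amounts. No available evidence explains why methoxy separates from chloro and ethyl.

From the compounds shown here alone, three groups at this position are too few to define a trend, so how an amine, a carboxylic acid or a longer chain such as propoxy would behave stays open. The compounds shown also cannot separate what the fluoro group itself contributes in compound 1 from what its place on the ring contributes.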